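This account rests on a few compounds, and the source may have more. Where it says the series, first, only, none or still open, it means among the compounds named here.

Compound 2 `Cc1ccc(S(=O)(=O)N2N=C(c3ccc(N4CCN(C)CC4)cc3)CC2c2ccc(N(C)C)cc2)cc1` has the higher number of the two compounds measured in a functional assay on HCC1806 cells (Homo sapiens) for inhibition, read by sulforhodamine B assay, tested at 10 uM; on this read-out lower numbers stand for less inhibition and higher numbers for more inhibition at the one concentration tested (going by the name of the read-out): in that assay compound 2 gives 32.2%, the highest of the two numbers, while the nearest, compound 1 `COC(=O)CC(=O)N1N=C(c2ccc(N3CCN(C)CC3)cc2)CC1c1ccc(N(C)C)cc1`, gives in this assay -8.3%. For the measured compounds named here, the one step available, a number 40.5 percentage points higher from compound 1 to compound 2 (beyond the scatter), concerns the substituent on the ring nitrogen of the shared core, (4-methylphenyl)sulfonyl in place of ((methoxycarbonyl)methyl)carbonyl.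

Compound 3 `CN1CCN(c2ccc(C3=NN(S(=O)(=O)c4ccc(C#N)cc4)C(c4ccc(N(C)C)cc4)C3)cc2)CC1` keeps the sulfonyl substitution of compound 2 and changes only the aryl of that sulfonyl: cyano in place of methyl on an aromatic carbon, that is (4-methylphenyl)sulfonyl to (4-cyanophenyl)sulfonyl. Going by the values given here, no measured step touches this aromatic carbon; the step from compound 1 to compound 2 exchanges the whole group on the ring nitrogen and so says little about swapping methyl for cyano on the aryl. With nothing in the series bearing directly on this change, the expectation for this assay is a step of no set direction, most likely within the scatter, so that a number 2.2 percentage points lower from compound 2 to compound 3 (within the scatter) is expected. On that basis compound 3 is estimated at 30% in this assay, with a range from 8% to 55%.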

Compound 3, a percentage reported as inhibition, at one concentration (the size of the read-out at that concentration, not a potency): 99.8%
Beside the measured number, compound 3's estimate is 69.8 percentage points below it; the measured number lies above the stated range.
By their numbers in this assay, from the lowest: compound 1; then compound 2; then compound 3.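

In this assay, the aromatic carbon para to a large group on the sulfonyl aryl proves to be a sensitive position: cyano in place of methyl gives a number 67.6 percentage points higher from compound 2 to compound 3 (beyond the scatter), a large step from a change on the aryl alone. The sulfonyl link by itself therefore does not fix the number, since two compounds that share it lie far apart, and the substituent on the aryl also matters. Exchanging the whole group on the ring nitrogen, with (4-cyanophenyl)sulfonyl in place of ((methoxycarbonyl)methyl)carbonyl, now gives a number 108.1 percentage points higher from compound 1 to compound 3 (beyond the scatter), and nothing at hand accounts for the difference between methyl and cyano at this carbon.

The compounds shown leave open whether this gain is particular to the nitrile or is shared by other groups on the same carbon, such as a nitro group, a chlorine, a methoxy group or a plain hydrogen. Also open, as far as these compounds go, are whether a nitrile on another carbon of that aryl would do the same and how compound 3 ranks in potency, as each number comes from a single concentration.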